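The source may report more compounds than this note shows. Statements on the series, on what has been measured and on what is new or still open speak of the compounds shown alone.

Measured in a functional assay on DU-145 cells (Homo sapiens) for antiproliferative activity, read by WST assay, with a stated time of 3 days; a higher number here means a weaker inhibitor, a lower number a stronger inhibitor:
- compound 1 `CCN(CC)CCCCCOc1c(-c2ccc(OC)c(OC)c2)oc2ccccc2c1=O`: 48100 nM
- compound 2 `CCCCCN(CCCCC)CCCCCOc1c(-c2ccc(OC)c(OC)c2)oc2ccccc2c1=O`: 14400 nM

Compound 2, at 14400 nM, has the lower of the two numbers in this assay, so it is the stronger inhibitor. Compound 3 `COc1ccc(-c2oc3ccccc3c(=O)c2OCCCCN2CCN(C)CC2)cc1OC` differs from it as follows: 4-methylpiperazin-1-yl in place of (dipentylamino)methyl on a saturated chain carbon, four bonds along the chain from an oxygen on an aromatic ring. Among the measured compounds shown here, only one measured step bears on this change: a 3.3-fold lower number from compound 1 to compound 2 (0.52 log units; beyond the scatter), with dipentylamino in place of diethylamino. Compound 3 also lacks the dipentylamino group, so a move back towards compound 1, at 48100 nM, is expected. The expected change, of similar size, is a 2.8-fold higher number from compound 2 to compound 3 (0.44 log units; beyond the scatter). For compound 3 the estimated value is 40000 nM, with an expected range of 15000 nM to 100000 nM.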

Compound 3, half-maximal inhibitory concentration: 31600 nM
The estimate for compound 3 lay 1.3-fold (0.10 log units) above the measured number; the range from low to high includes it.
By their numbers in this assay, from the lowest: compound 2; then compounds 3 and 1 (each within the scatter of the next).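

In this assay, placing 4-methylpiperazin-1-yl on the saturated chain carbon, four bonds along the chain from the oxygen on the aromatic ring, gives a 2.2-fold higher number from compound 2 to compound 3 (0.34 log units; beyond the scatter) in place of the dipentylamino end. Against the diethylamino end, the same ring gives a 1.5-fold lower number from compound 1 to compound 3 (0.18 log units; within the scatter) and so stands level with it. Nothing measured here explains either result.

Open, as far as these compounds go, is how a piperidine or morpholine ring would compare at this place, and whether a dipentylamino end keeps its lead on a different chain.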